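Swapping the Chain Amine on a Toll-like Receptor 9 Antagonist

This account rests on a few compounds, and the source may have more. Where it says the series, first, only, none or still open, it means among the compounds named here.

Compound 1 `Nc1nc(N2CCN(C3CCCC3)CC2)c2ncn(CCCN3CCCC3)c2n1`: 120 nM
Compound 2 `CCN1CCN(CCCn2cnc3c(N4CCN(CC)CC4)ncnc32)CC1`: 1190 nM
Compound 3 `CCN1CCN(CCCn2cnc3c(N4CCN(CC)CC4)nc(N)nc32)CC1`: 260 nM

All three were tested in an assay on HEK293 cells for antagonist activity at Toll-like receptor 9 (Homo sapiens), read by spectrophotometry; on this read-out higher numbers stand for weaker inhibition and lower numbers for stronger inhibition. Compound 3 gives the second highest number of the three: compound 1 sits below it and compound 2 above it, both beyond the usual scatter. Among the compounds with values here, the only measured single-point step is a 4.6-fold lower number from compound 2 to compound 3 (0.66 log units; beyond the scatter), in which an amino group enters on an aromatic carbon. Compound 4 `CCN1CCN(c2nc(N)nc3c2ncn3CCCN2CCCC2)CC1` arises from compound 3 by pyrrolidin-1-yl in place of 4-ethylpiperazin-1-yl on a saturated chain carbon, three bonds along the chain from an aromatic nitrogen. Within the data shown here, no measured step bears directly on this change, so the expectation leans on compound 1, which carries the same pyrrolidin-1-yl chain end and gives 120 nM. The number for compound 4 is therefore expected to move by a 1.7-fold lower number from compound 3 to compound 4 (0.24 log units; within the scatter), a modest fall. The estimate for compound 4 is 150 nM, within 50 nM to 450 nM.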

Compound 4, half-maximal inhibitory concentration: 190 nM
Estimate against measurement, compound 4: 1.3-fold (0.10 log units) below; the range from low to high includes it.
By their numbers in this assay, from the lowest: compounds 1, 4 and 3 (each within the scatter of the next, the first and the last beyond it); then compound 2.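

Pyrrolidin-1-yl in place of 4-ethylpiperazin-1-yl on the chain gives (a 1.4-fold lower number from compound 3 to compound 4 (0.14 log units; within the scatter)), so the two chain ends cannot be told apart in this assay. The same holds for ethyl in place of cyclopentyl on the ring amine nitrogen (a 1.6-fold higher number from compound 1 to compound 4 (0.20 log units; within the scatter)). Nothing available here explains why either swap leaves the number within the scatter.

Still open, on these data alone, is whether the chain end needs an amine at all, which a hydroxyl group in place of pyrrolidin-1-yl would test. A longer chain carrying the pyrrolidin-1-yl is also untested among these compounds.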